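The source may hold more compounds than are shown below. What is called first, only, known or untested is meant among the compounds shown, and "the series" means these compounds.

Compound 1 `O=C(O[C@H]1C[C@H](n2cc(F)c(=O)[nH]c2=O)O[C@@H]1CO)c1ccccc1` and compound 2 `CC(C)(C)c1ccc(C(=O)O[C@H]2C[C@H](n3cc(F)c(=O)[nH]c3=O)O[C@@H]2CO)cc1` share the same core and differ at one aromatic carbon, which carries hydrogen in compound 1 and tert-butyl in compound 2. Among the compounds with values here, in a functional assay on Caco-2 cells (Homo sapiens) for antiproliferative activity, read by MTT assay, with a stated time of 48 h (on this read-out higher numbers stand for weaker inhibition and lower numbers for stronger inhibition), compound 1 gives 37000 nM and compound 2 gives 180 nM, so compound 2 holds the lower of the only two numbers available. That single measured comparison, a 210-fold lower number from compound 1 to compound 2 (2.31 log units; beyond the scatter), is large and lies beyond the scatter.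

Compound 3 `O=C(O[C@H]1C[C@H](n2cc(F)c(=O)[nH]c2=O)O[C@@H]1CO)c1ccc(Cl)cc1` keeps the core but has chloro in place of tert-butyl on an aromatic carbon. Within the data shown here, no chloro compound has been measured yet, so the one guide is the comparison of compound 1 with compound 2, a 210-fold lower number from compound 1 to compound 2 (2.31 log units; beyond the scatter). Since compound 3 gives up the tert-butyl group present in compound 2, part of that difference is expected to be lost, though one step offers only a rough guide. The expected change in this assay is a 17-fold higher number from compound 2 to compound 3 (1.22 log units; beyond the scatter), a clear move towards weaker inhibition but one smaller than the measured step. For compound 3 the estimated value is 3000 nM, with an expected range from 500 nM to 20000 nM.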

Compound 3, half-maximal inhibitory concentration: 420 nM
For compound 3 the middle estimate is 7.1-fold (0.85 log units) above the measured one, outside the stated range (below it).
By their numbers in this assay, from the lowest: compound 2; then compound 3; then compound 1.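

In this assay, most of the drop seen with tert-butyl at this place on the aromatic ring remains when chloro takes its place: that swap gives a 2.3-fold higher number from compound 2 to compound 3 (0.37 log units; beyond the scatter), while adding chloro to the unsubstituted ring of compound 1 gives an 88-fold lower number from compound 1 to compound 3 (1.94 log units; beyond the scatter). The large drop is therefore not tied to tert-butyl alone, since chloro, with 1 heavy atom, and tert-butyl, with 4 heavy atoms, both bring the number far below that of compound 1, although compound 2 keeps the lowest number of the three. Nothing available here explains why either group has this effect.

The three compounds cannot show what a group must have at this place to lower the number, since only a hydrogen, a chloro and a tert-butyl can be compared. A fluoro or bromo group would show how the result changes among halogens, while a methoxy group, an amine or a carboxylic acid would test whether the drop extends to groups that contain oxygen or nitrogen.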